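Furan in Place of Hydroxyphenyl: Expected Edema Inhibition

This account rests on a few compounds, and the source may have more. Where it says the series, first, only, none or still open, it means among the compounds named here.

Compound 1 `NS(=O)(=O)c1ccc(N2N=C(c3cccc(O)c3)C[C@H]2c2ccccc2)cc1`: 77.7%
Compound 2 `COc1ccc([C@@H]2CC(c3cccc(O)c3)=NN2c2ccc(S(N)(=O)=O)cc2)cc1`: 62.9%
Compound 3 `NS(=O)(=O)c1ccc(N2N=C(c3cccc(O)c3)C[C@H]2c2ccccc2O)cc1`: 55.5%

In a functional assay on the whole organism (strain Wistar albino) for inhibition, with Rattus norvegicus as the target, read by paw edema, with stated times of 30 min and 5 h, at a dose of 0.05 mmol/kg (on this read-out lower numbers stand for less inhibition and higher numbers for more inhibition at the one dose given (going by the name of the read-out)), compound 3 shows the lowest of the three numbers, though compound 2 sits within the scatter of it; only compound 1 is clearly apart, as a number 22.2 percentage points lower from compound 1 to compound 3 (beyond the scatter) shows. Compound 4 `NS(=O)(=O)c1ccc(N2N=C(c3cccc(O)c3)C[C@H]2c2ccco2)cc1` differs from compound 3 in one place: furan-2-yl in place of 2-hydroxyphenyl on a saturated ring carbon. Within the data shown here, two steps bear on this. Changing the group on that saturated ring carbon gave a number 7.4 percentage points lower from compound 2 to compound 3 (within the scatter), within the scatter. Adding the hydroxy gave a number 22.2 percentage points lower from compound 1 to compound 3 (beyond the scatter), beyond it, and compound 4 has no such hydroxy. A modest rise is therefore expected, a number 9.5 percentage points higher from compound 3 to compound 4 (within the scatter). Compound 4 is estimated at 65%, between 50% and 80%.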

Compound 4, a percentage reported as inhibition, in the whole organism at one dose (the size of the read-out at that dose, not a potency): 29.6%
Estimate against measurement, compound 4: 35.4 percentage points above; the whole stated range lies above it.
By their numbers in this assay, from the lowest: compound 4; then compounds 3 and 2 (each within the scatter of the next); then compound 1.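

On this saturated ring carbon, furan-2-yl gives a number 25.9 percentage points lower from compound 3 to compound 4 (beyond the scatter) and a number 33.3 percentage points lower from compound 2 to compound 4 (beyond the scatter) and a number 48.1 percentage points lower from compound 1 to compound 4 (beyond the scatter) in this assay so compound 4 is clearly the lowest of the four. Compound 4 has no hydroxy, yet its number does not recover, so adding groups to the phenyl costs less than replacing that ring with furan-2-yl. No data here explain the drop.

On these data alone, whether a thiophene or pyridine ring here would behave like phenyl or like furan-2-yl stays open. So does whether a saturated cyclohexyl group would retain any inhibition.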